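This account rests on a few compounds, and the source may have more. Where it says the series, first, only, none or still open, it means among the compounds named here.

In a functional assay on PC-3 cells (Homo sapiens) for antiproliferative activity, read by MTT assay, with a stated time of 72 h (a lower number here means a stronger inhibitor, a higher number a weaker inhibitor), compound 1 `CC(=O)NNC(=O)c1csc2ncc(-c3ccc(C)cc3)n12` gives 92700 nM while compound 2 `CCC(=O)NNC(=O)c1csc2ncc(-c3ccc(C)cc3)n12` gives 18500 nM and compound 3 `COc1ccc(-c2cnc3scc(C(=O)NNC(C)=O)n23)cc1` gives 28300 nM on the same scale. Compound 3 therefore sits within the usual scatter of compound 2 and clearly under compound 1, having come from it by methoxy in place of methyl on an aromatic carbon, which gave a 3.3-fold lower number from compound 1 to compound 3 (0.52 log units; beyond the scatter) in this small set.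

Compound 4 `CCC(=O)NNC(=O)c1csc2ncc(-c3ccc(OC)cc3)n12` differs from compound 3 by one change, (methyl in place of hydrogen on a saturated chain carbon bound to a carbonyl carbon), which turns acetyl to propanoyl. The same change has been measured only once, as a 5.0-fold lower number from compound 1 to compound 2 (0.70 log units; beyond the scatter), and there the aromatic carbon carried methyl rather than methoxy. Going by these compounds, whether it carries over in full is unknown, so a step in the same direction, possibly somewhat smaller, is expected. The expected step is a 3.8-fold lower number from compound 3 to compound 4 (0.58 log units; beyond the scatter) for this pair. For compound 4 the estimated value is 7500 nM with a likely range from 3000 nM to 18000 nM in this test.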

Compound 4, half-maximal inhibitory concentration: 79800 nM
Estimate against measurement, compound 4: 11-fold (1.03 log units) below; the measured number lies above the stated range.
By their numbers in this assay, from the lowest: compounds 2 and 3 (each within the scatter of the next); then compounds 4 and 1 (each within the scatter of the next).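

Adding one carbon to the acetyl chain does not have a fixed effect in this set: with methoxy on the aromatic carbon, the number rises (a 2.8-fold higher number from compound 3 to compound 4 (0.45 log units; beyond the scatter)), the opposite direction from the methyl series: the same change on two cores in this assay, a 5.0-fold lower number (0.70 log units; beyond the scatter) from compound 1 to compound 2 and a 2.8-fold higher number (0.45 log units; beyond the scatter) from compound 3 to compound 4, 14-fold (1.15 log units) apart, beyond the scatter of two such steps.
The aromatic change also reverses once the chain is propanoyl (a 4.3-fold higher number from compound 2 to compound 4 (0.63 log units; beyond the scatter)), although it lowered the number with the acetyl chain: the same change on two cores in this assay, a 3.3-fold lower number (0.52 log units; beyond the scatter) from compound 1 to compound 3 and a 4.3-fold higher number (0.63 log units; beyond the scatter) from compound 2 to compound 4, 14-fold (1.15 log units) apart, beyond the scatter of two such steps.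
The effects of these two places therefore do not simply add, so the result of either change depends on the group present at the other.

These four compounds do not explain this dependence. A longer chain such as butanoyl, or an amine such as dimethylamino on the aromatic carbon, would test whether it extends beyond this small set.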